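The source may hold more compounds than are shown below. What is called first, only, known or untested is meant among the compounds shown, and "the series" means these compounds.

Compounds measured in a functional assay on HCT-116 cells (Homo sapiens) for cytotoxicity, read by MTT assay, with a stated time of 72 h (on this read-out lower numbers stand for stronger inhibition and higher numbers for weaker inhibition), are these
compound 1 `CN(C)CCCCCn1c2c(c3ccccc31)C(=O)c1c[n+]([O-])c3ccccc3c1C2=O` gives 470 nM
compound 2 `O=C1c2c[n+]([O-])c3ccccc3c2C(=O)c2c1c1ccccc1n2CCN1CCCC1` gives 270 nM
compound 3 `CCCCN1CCN(CCCCn2c3c(c4ccccc42)C(=O)c2c[n+]([O-])c4ccccc4c2C3=O)CC1` gives 1920 nM

Compound 3 at 1920 nM has the highest number of the three and is the weakest of them in this assay here. Two measured steps lead up to it: one is a 4.1-fold higher number from compound 1 to compound 3 (0.61 log units; beyond the scatter) and the other is a 7.1-fold higher number from compound 2 to compound 3 (0.85 log units; beyond the scatter) and both are modest but real. The step of a 1.7-fold lower number from compound 1 to compound 2 (0.24 log units; within the scatter) separates the other two compounds by no more than ordinary scatter.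

The next compound is compound 4 `CN1CCN(CCCn2c3c(c4ccccc42)C(=O)c2c[n+]([O-])c4ccccc4c2C3=O)CC1` and the change from compound 3 is 4-methylpiperazin-1-yl in place of (4-butylpiperazin-1-yl)methyl on a saturated chain carbon, three bonds along the chain from an aromatic nitrogen with 4-methylpiperazin-1-yl in place of (4-butylpiperazin-1-yl)methyl on a saturated chain carbon, three bonds along the chain from an aromatic nitrogen. Within the data shown here, no measured compound carries the 4-methylpiperazin-1-yl group, so this change has no direct precedent. Among the measured compounds shown here, the best guide is that compound 3, the only one with a butyl group on a piperazine, sits above compound 1 by the step of a 4.1-fold higher number from compound 1 to compound 3 (0.61 log units; beyond the scatter) and this suggests a partial return toward the lower values. The expected move is a 3.0-fold lower number from compound 3 to compound 4 (0.47 log units; beyond the scatter) in the direction of stronger inhibition, though this is uncertain. For compound 4 the estimated value is 650 nM with an expected range from 220 nM to 1900 nM in this measurement.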

Compound 4, half-maximal inhibitory concentration: 560 nM
Compound 4: middle estimate off by 1.2-fold (0.06 log units), on the high side, and the stated range covers the measured number.
By their numbers in this assay, from the lowest: compounds 2, 1 and 4 (each within the scatter of the next, the first and the last beyond it); then compound 3.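

In this assay, among these compounds, 4-methylpiperazin-1-yl in place of (4-butylpiperazin-1-yl)methyl gives a 3.4-fold lower number from compound 3 to compound 4 (0.54 log units; beyond the scatter) and so shows that a piperazine ring on this chain can go with a much lower number than the one seen for compound 3, although the ring itself stays. Compound 4 also gives a 1.2-fold higher number from compound 1 to compound 4 (0.08 log units; within the scatter) and this places it within ordinary scatter of the compound with the dimethylamino group, while a 2.1-fold higher number from compound 2 to compound 4 (0.32 log units; beyond the scatter) is a modest step beyond the scatter against the pyrrolidine compound. No accompanying measurement explains these differences.

As far as these compounds go, the step from compound 3 changes two things at once, the chain length and the butyl group on the piperazine, so the share of each stays unknown, and a 4-butylpiperazin-1-yl group on the chain of compound 4 would be needed to separate them. Also open, from the compounds shown here alone, is how other amines on this chain would behave, such as a morpholine, a piperidine or a primary amine, and whether a piperazine carrying an ethyl or acetyl group would fall nearer compound 4 or compound 3.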